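The source may hold more compounds than are shown below. What is called first, only, known or untested is meant among the compounds shown, and "the series" means these compounds.

Measured compounds:
Compound 1, `Cc1nc(-c2ccccc2)c(C(=O)N2CCN(c3ccccc3Cl)CC2)o1`, gives 124 nM in a functional assay on HL-60 cells (Homo sapiens) for inhibition, read by MTT assay, with a stated time of 72 h; on this read-out lower numbers stand for stronger inhibition and higher numbers for weaker inhibition.
Compound 2, `COc1cccc(N2CCN(C(=O)c3oc(C)nc3-c3ccccc3F)CC2)c1`, gives 56.1 nM in this assay.
Compound 3, `Cc1ccc(C)c(N2CCN(C(=O)c3oc(C)nc3-c3cccc(F)c3)CC2)c1`, gives 204 nM in this assay.

Among these three numbers compound 1 holds the second highest. Its nearest neighbour is compound 3, whose number lies within the scatter of repeated measurements of that of compound 1, so the two cannot be told apart on this read-out. Compound 2 stands furthest away, with a number lower than that of compound 1 by more than the scatter.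

Compound 4, `Cc1nc(-c2ccccc2)c(C(=O)N2CCN(c3cc(Cl)cc(Cl)c3)CC2)o1`, has not yet been measured in this assay. It differs from compound 1 in one place: 3,5-dichlorophenyl in place of 2-chlorophenyl on an amine nitrogen in a ring. Going by the values given here, no measured pair in this set shows that same change, so nothing in the data fixes its size or direction. The account therefore expects only a small step, most likely none beyond the scatter, with a slight lean toward a higher number. The estimate for compound 4 in this assay is 200 nM, within a range from 60 nM to 700 nM. That estimate means an expected step of a 1.6-fold higher number from compound 1 to compound 4 (0.21 log units; within the scatter).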

Compound 4, half-maximal inhibitory concentration: 41.8 nM
For compound 4 the middle estimate is 4.8-fold (0.68 log units) above the measured one, outside the stated range (below it).
By their numbers in this assay, from the lowest: compounds 4 and 2 (each within the scatter of the next); then compounds 1 and 3 (each within the scatter of the next).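

In this assay, 3,5-dichlorophenyl in place of 2-chlorophenyl on an amine nitrogen in a ring gives a 3.0-fold lower number from compound 1 to compound 4 (0.47 log units; beyond the scatter), a modest step toward stronger inhibition. Going by these compounds alone, the earlier compounds offered no pair differing in one place, so this is the first direct sign that the group on this nitrogen can shift the read-out beyond the scatter, and it does so in the direction of the lower number. Nothing available here accounts for the step, which rests on this single pair.

The compounds shown leave open whether one chlorine would be enough, as in 3-chlorophenyl, and how plain phenyl or 3,5-dimethylphenyl would read on this nitrogen. They also leave open whether the same change would give a similar step where the phenyl on the core carries fluorine.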